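Cyanomethoxy ring substituent and cytotoxicity in liver cells

The compounds below may be only part of what the source reports. "The series", "measured", "known", "first", "only" and "open" are said of these compounds alone.

Compound 1 `CC(C)CCn1nc(-c2cccs2)c(O)c(C2=NS(=O)(=O)c3ccccc3N2)c1=O` gives > 33000 nM, which is a limit of the assay and not a number.
Compound 2 `CC(C)CCn1nc(-c2cccs2)c(O)c(C2=NS(=O)(=O)c3cc(OCC(N)=O)ccc3N2)c1=O` gives 78000 nM.
Compound 3 `CC(C)CCn1nc(-c2cccs2)c(O)c(C2=NS(=O)(=O)c3cc(OC(C)(C)C(N)=O)ccc3N2)c1=O` gives > 33000 nM, again a limit rather than a number.

These three values come from an ADME assay on Huh-7 cells (Homo sapiens) for cytotoxicity, with a stated time of 72 h; on this read-out lower numbers stand for higher toxicity in this test and higher numbers for lower toxicity in this test. Within the data shown here, compound 1 stands only at a limit, and one of the other two values is a limit as well; the one read number, that of compound 2, lies far from the toxic end of the scale. The steps a step that the limit leaves unreadable from compound 1 to compound 2, a step that the two limits leave unreadable from compound 1 to compound 3 and a step that the limit leaves unreadable from compound 2 to compound 3 therefore cannot be sized, because of the limit of > 33000 nM in this assay, at which 2 of the 3 values shown sit.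

Compound 4 `CC(C)CCn1nc(-c2cccs2)c(O)c(C2=NS(=O)(=O)c3cc(OCC#N)ccc3N2)c1=O` differs from compound 1 by cyanomethoxy in place of hydrogen on an aromatic carbon. The closest measured change is that from compound 1 to compound 2, a different group in the same place, which left cytotoxicity low. Among the measured compounds shown here, no measured step gives a readable size, so no movement beyond the scatter in this assay is expected, and a low level of toxicity is expected for compound 4 as well. The expected step from compound 1 is a step that the limit leaves unreadable from compound 1 to compound 4. Compound 4 is estimated at 70000 nM, between 33000 nM and 200000 nM, with a fair chance that only a limit is reported.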

Compound 4, half-maximal cytotoxic concentration: > 33000 nM
Compound 4: a limit, no number; the forecaster's own chance of this, stated with the estimate: 60%; the middle value does not contradict the limit.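

Compound 4 gives > 33000 nM, which is a limit and not a number. Its steps from compound 1, compound 2 and compound 3 cannot be read: the limit of > 33000 nM in this assay, at which 3 of the 4 values shown sit.

The compounds shown leave open how toxic compound 1, compound 3 and compound 4 actually are in this assay, and whether cyanomethoxy in place of hydrogen changes that toxicity at all.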